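Amino-methyl variations on a shared oxadiazolethione core

This account rests on a few compounds, and the source may have more. Where it says the series, first, only, none or still open, it means among the compounds named here.

Measured so far:
- compound 1, `CCCCCCCCCCCCCCCCNCn1nc(-c2ccc3c(c2)OCCO3)oc1=S`: 22900 nM
- compound 2, `Fc1cccc(NCn2nc(-c3ccc4c(c3)OCCO4)oc2=S)c1`: 6620 nM
- compound 3, `FC(F)(F)c1cc(NCn2nc(-c3ccc4c(c3)OCCO4)oc2=S)cc(C(F)(F)F)c1`: 9320 nM

In a functional assay, with a stated time of 6 min (on this read-out higher numbers stand for weaker inhibition and lower numbers for stronger inhibition), compound 2 gives the lowest number of the three, but compound 3 lies within the scatter of it, so no order between those two is claimed; compound 1 sits beyond the scatter above compound 2.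

Compound 4, `S=c1oc(-c2ccc3c(c2)OCCO3)nn1CNc1ccc(Br)cc1`, has not been measured. It differs from compound 2 as follows: 4-bromophenyl in place of 3-fluorophenyl on an amine nitrogen

Among the compounds with values here, no step between measured compounds informs this change, so a step from compound 2 to compound 4 no larger than the scatter is expected, in either direction. Compound 4 is therefore estimated at 6000 nM, range 2500 nM to 15000 nM, an expected step of a 1.1-fold lower number from compound 2 to compound 4 (0.04 log units; within the scatter).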

Compound 4, half-maximal inhibitory concentration: 14700 nM
Compound 4: middle estimate off by 2.5-fold (0.39 log units), on the low side; the range from low to high includes it.
By their numbers in this assay, from the lowest: compounds 2, 3, 4 and 1 (each within the scatter of the next, the first and the last beyond it).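

In this assay, within the data shown here, the aryl group on the amine nitrogen makes a readable difference: 4-bromophenyl in place of 3-fluorophenyl gives a 2.2-fold higher number from compound 2 to compound 4 (0.35 log units; beyond the scatter), the first one-place step, and a modest one. Nothing at hand bears on why the number rises.

The change swaps the halogen and also alters where it sits on the ring, so the two cannot be separated from these compounds. On these data alone, how an unsubstituted phenyl, a chlorophenyl or a carboxylic acid on the ring would behave at this position remains open.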